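This account rests on a few compounds, and the source may have more. Where it says the series, first, only, none or still open, it means among the compounds named here.

Compound 1 `O[C@H](COCCOC[C@@H](O)Cc1cn(Cc2ccc3ccccc3c2)nn1)Cc1ccc(-c2ccccc2)cc1` carries a (naphthalen-2-yl)methyl on the aromatic nitrogen of its triazole, and in a functional assay on HCT-116 cells (Homo sapiens) for inhibition, read by MTT assay, with a stated time of 72 h (on this read-out higher numbers stand for weaker inhibition of growth and lower numbers for stronger inhibition of growth), compound 1 gives 8600 nM. Compound 2 `O[C@H](COCCOC[C@@H](O)Cc1cn(-c2cncnc2)nn1)Cc1ccc(-c2ccccc2)cc1` bears a pyrimidin-5-yl at that position instead. In this assay compound 2 reaches only a limit, > 100000 nM, so the limit of > 100000 nM in this assay, at which 1 of the 3 values shown sits, holds for it. Compound 3 `O[C@H](COCCOC[C@@H](O)Cc1cn(-c2cccnc2)nn1)Cc1ccc(-c2ccccc2)cc1` has a pyridin-3-yl there, and in this assay compound 3 gives 46800 nM, the highest of the two numbers measured, with compound 1 the nearest. The steps are an at least 11-fold higher number from compound 1 to compound 2 (1.06 log units; beyond the scatter), a 5.4-fold higher number from compound 1 to compound 3 (0.74 log units; beyond the scatter) and an at least 2.1-fold lower number from compound 2 to compound 3 (0.32 log units; beyond the scatter).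

Compound 4 `O=c1[nH]c2ccc(-n3cc(C[C@H](O)COCCOC[C@@H](O)Cc4ccc(-c5ccccc5)cc4)nn3)cc2s1` differs from compound 3 in one place: a group of 10 heavy atoms (7 carbon, 1 nitrogen, 1 oxygen, 1 sulfur; one five-membered aromatic ring with 2 hetero atoms, one six-membered aromatic ring of carbon only) in place of a group of 6 heavy atoms (5 carbon, 1 nitrogen; one six-membered aromatic ring with 1 hetero atom), on an aromatic nitrogen. Both measured steps from the bicyclic group of compound 1 to a small six-membered heteroaryl raised the number, a 5.4-fold higher number from compound 1 to compound 3 (0.74 log units; beyond the scatter) and an at least 11-fold higher number from compound 1 to compound 2 (1.06 log units; beyond the scatter); a return to a two-ring group is therefore expected to lower it, by about a 3.1-fold lower number from compound 3 to compound 4 (0.49 log units; beyond the scatter). The estimate for compound 4 in this assay is 15000 nM, between 4000 nM and 60000 nM.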

Compound 4, concentration for 50% growth inhibition: 9200 nM
Beside the measured number, compound 4's estimate is 1.6-fold (0.21 log units) above it; the range from low to high includes it.
By their numbers in this assay, from the lowest: compounds 1 and 4 (each within the scatter of the next); then compound 3. At a limit, above all of these: compound 2.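

In this assay, a two-ring group on the aromatic nitrogen brings back what the pyridin-3-yl gave up, with a 5.1-fold lower number from compound 3 to compound 4 (0.71 log units; beyond the scatter). Set against the (naphthalen-2-yl)methyl, the change reads a 1.1-fold higher number from compound 1 to compound 4 (0.03 log units; within the scatter), so among these compounds neither an all-carbon two-ring group nor its methyl link is required at this position, and a group with ring hetero atoms, a double bond outside the rings and a hydrogen-bond donor serves equally. The largest change, an at least 10-fold lower number from compound 2 to compound 4 (1.03 log units; beyond the scatter), rests on a limit and not on a number: the limit of > 100000 nM in this assay, at which 1 of the 4 values shown sits.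

The compounds shown do not separate the two-ring size of the entering group from its hydrogen-bond donor, which a quinolin-3-yl or a plain benzyl would address. As far as these compounds go, how a carboxylic acid or an amine on this group would read also remains open.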